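The compounds below may be only part of what the source reports. "The series", "measured", "known", "first", "only" and "open" are said of these compounds alone.

In a physicochemical assay for solubility (on this read-out higher numbers stand for higher solubility and lower numbers for lower solubility), compound 2 `CNC(=O)c1cc(C(=O)NC2CC2)cn(Cc2cccc(C)c2)c1=O` stands at >= 205 ug/mL, which is a limit and not a number. Compound 1 `CNC(=O)c1cc(C(=O)NC2CC2)cn(Cc2cccc([C@@H](C)O)c2)c1=O` gives >= 131 ug/mL, also a limit. Among the compounds with values here, the only measured step, a step that the two limits leave unreadable from compound 1 to compound 2, has no readable size, so it sets no scale for what follows. Compound 3 `CNC(=O)c1cc(C(=O)NC2CC2)cn(CC2CCCOC2)c1=O` has oxan-3-yl in place of 3-methylphenyl on a saturated chain carbon bound to an aromatic nitrogen. Within the data shown here, no measured step covers this change, so only a tentative upward move is expected. The expected change is a step that the limit leaves unreadable from compound 2 to compound 3. Compound 3 is estimated at 300 ug/mL, with an expected range from 150 ug/mL to 700 ug/mL.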

Compound 3, solubility: >= 131 ug/mL
Compound 3: no number, only a limit; the forecaster's own chance of this, stated with the estimate: 65%; the middle value is on the limit's open side.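

In this assay compound 3 gives >= 131 ug/mL, which is a limit and not a number. Within the data shown here, no step from compound 1 or compound 2 to compound 3 can be read. The compounds shown leave open how these three compounds actually order in this assay.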